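A few compounds are considered here, and "the series" means these few. Any claim that something is new, unique, unknown or untested is made for them only; others in the source may bear on it.

Measured in a toxicity assay on HepG2 2.2.15 cells (Homo sapiens) for cytotoxicity, read by CCK-8 assay, with a stated time of 8 days; on this read-out lower numbers stand for higher toxicity in this test and higher numbers for lower toxicity in this test:
Compound 1 `CC(C)Cc1nn(-c2nccs2)cc1C(=O)NCc1cccc(F)c1` gives > 100000 nM, a limit of the assay.
Compound 2 `CC(C)Cc1nn(-c2nccs2)cc1C(=O)Nc1ccc(F)cc1` gives 83700 nM.
Compound 3 `COc1ccc(CNC(=O)c2cn(-c3nccs3)nc2CC(C)C)cc1` gives > 100000 nM, again a limit.

Compound 3 thus stands at the top of the tested range in this assay, where (the limit of > 100000 nM in this assay, at which 2 of the 3 values shown sit). Compound 4 `CC(C)Cc1nn(-c2nccs2)cc1C(=O)NCc1ccccc1F` differs from it in one place: 2-fluorophenyl in place of 4-methoxyphenyl on a saturated chain carbon bound to an amide-type nitrogen. For the measured compounds named here, two measured steps bear on this change. Because a step that the two limits leave unreadable from compound 1 to compound 3 runs between two limits, its size cannot be read. The step of an at least 1.1-fold lower number from compound 1 to compound 2 (0.07 log units; that floor lies within the scatter) lies within the scatter. Compound 1 carries 3-fluorophenyl on a saturated chain carbon bound to an amide-type nitrogen and sits at the limit, so a fluorinated ring at that place has not yet lowered the number. For compound 4 the expectation is therefore no step beyond the scatter, a number no higher from compound 3 to compound 4 (the limit leaves the size open), most likely again a limit. Compound 4 is estimated at 100000 nM, within 50000 nM to 300000 nM.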

Compound 4, half-maximal cytotoxic concentration: > 100000 nM
Compound 4 ended at the assay's limit; the forecaster's own chance of this, stated with the estimate: 75%; the middle value lies on the limit itself.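

In this assay, 2-fluorophenyl now joins 3-fluorophenyl and 4-methoxyphenyl on a saturated chain carbon bound to an amide-type nitrogen, and all three sit at a limit, so moving the fluorine or swapping it for methoxy brings no visible change: the limit of > 100000 nM in this assay, at which 3 of the 4 values shown sit. The change from 4-fluorophenyl to 2-fluorobenzyl on an amide-type nitrogen gives an at least 1.1-fold higher number from compound 2 to compound 4 (0.07 log units; that floor lies within the scatter). The steps among the compounds at the limit cannot be read.

As far as these compounds go, how far compound 1, compound 3 and compound 4 truly differ stays open. Also open, from the compounds shown here alone, is whether an amine or a carboxylic acid in place of this ring would bring the number into the readable range.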